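The compounds below may be only part of what the source reports. "The series", "measured", "known", "first", "only" and "open" are said of these compounds alone.

Compound 2 `CC(C)C(CC(=O)OCC1(CO)C/C(=C\c2ccc(C(=O)O)cc2)C(=O)O1)C(C)C` and compound 1 `CC(C)CC(CC(=O)OCC1(CO)C/C(=C\c2ccc(C(=O)O)cc2)C(=O)O1)CC(C)C` share the same core and differ only in the branched alkyl chain attached to the ester. In an assay for displacement of a labelled ligand from protein kinase C delta type (Mus musculus), with a stated time of 30 min, in the presence of a further agent that is not named here (on this read-out higher numbers stand for weaker binding and lower numbers for tighter binding), compound 1 gives 96 nM, and in the same assay compound 2 gives 560 nM. Among the measured compounds shown here, of the two numbers recorded, compound 2 therefore stands at the higher one, and the only measured step, a 5.8-fold higher number from compound 1 to compound 2 (0.77 log units; beyond the scatter), describes that difference in the alkyl chain.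

Compound 3 `CC(C)C(CC(=O)OCC1(CO)C/C(=C\c2ccc(O)cc2)C(=O)O1)C(C)C` is not yet measured. It keeps the alkyl chain of compound 2 and changes the aromatic substituent instead: hydroxy in place of carboxy on an aromatic carbon. The single measured step concerns the alkyl chain and says nothing about a change on the aromatic ring, so no measured step bears on this substitution, and the direction of any effect in this assay cannot be read from the two numbers shown.

With that in mind, compound 3 is estimated at 350 nM, with a range from 70 nM to 1800 nM, which corresponds to an expected step of a 1.6-fold lower number from compound 2 to compound 3 (0.20 log units; within the scatter) and is wide enough to allow a change in either direction.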

Compound 3, dissociation constant: 2.95 nM
Beside the measured number, compound 3's estimate is 120-fold (2.07 log units) above it, and the stated range ends above it.
By their numbers in this assay, from the lowest: compound 3; then compound 1; then compound 2.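

In this assay, among the compounds shown here, hydroxy in place of carboxy on an aromatic carbon, para to a large group, gives a 190-fold lower number from compound 2 to compound 3 (2.28 log units; beyond the scatter), so this position, which stayed the same in the earlier compounds, can move the binding read-out strongly. This step is much larger than the only earlier one, a 5.8-fold higher number from compound 1 to compound 2 (0.77 log units; beyond the scatter), which concerned the alkyl chain; among the changes shown, going from 4-carboxyphenyl to 4-hydroxyphenyl therefore counts for more than the change of chain. Nothing available here accounts for the tighter binding of compound 3.

Going by these compounds, whether the shift comes from the presence of hydroxy or from the loss of carboxy remains open, as only these two groups are compared at this position, and a plain hydrogen, a methoxy or an amine there would help to separate the two readings. Also open, on these data alone, is whether a step of this size would carry over to the 1-isobutyl-3-methylbutyl chain of compound 1, or whether the two changes would combine in some other way.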